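Swapping the amide aryl group: compound 2 to compound 3

The compounds below may be only part of what the source reports. "The series", "measured", "known", "first", "only" and "open" are said of these compounds alone.

compound 1 `CCc1ccccc1C(=O)Nc1ccc2nc(N3CCN(CC)CC3)cc(C)c2c1` 15800 nM
compound 2 `CCN1CCN(c2cc(C)c3cc(NC(=O)c4cc5ccccc5[nH]4)ccc3n2)CC1` 2950 nM

In a functional assay on MCF7 cells (Homo sapiens) for antiproliferative activity, read by MTT assay, with a stated time of 72 h (a higher number here means a weaker inhibitor, a lower number a stronger inhibitor), compound 2 gives 2950 nM, the lowest of the two numbers; the nearest is compound 1 with 15800 nM. Compound 3 `CCN1CCN(c2cc(C)c3cc(NC(=O)c4ccc(Cl)c(Cl)c4)ccc3n2)CC1` differs from compound 2 in one place: 3,4-dichlorophenyl in place of 1H-indol-2-yl on a carbonyl carbon. Going by the values given here, the one measured step at this carbonyl carbon is a 5.4-fold lower number from compound 1 to compound 2 (0.73 log units; beyond the scatter), which bears directly on this change because a 5.4-fold lower number from compound 1 to compound 2 (0.73 log units; beyond the scatter) also exchanged the aryl group on the carbonyl carbon. The change in compound 3 moves the aryl group back toward a plain phenyl, so a rise is expected, a 2.4-fold higher number from compound 2 to compound 3 (0.38 log units; beyond the scatter). For compound 3 the estimate is 7000 nM, within 2000 nM to 25000 nM.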

Compound 3, half-maximal inhibitory concentration: 1380 nM
For compound 3 the middle estimate is 5.1-fold (0.71 log units) above the measured one, outside the stated range (below it).
By their numbers in this assay, from the lowest: compound 3; then compound 2; then compound 1.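

Compound 3 shows that a single carbon-only ring with no hydrogen-bond donor on this carbonyl carbon can give a lower number than the indole, with a 2.1-fold lower number from compound 2 to compound 3 (0.33 log units; beyond the scatter) in this assay. Compound 1 also carries a single carbon-only ring with no donor, yet there is an 11-fold lower number from compound 1 to compound 3 (1.06 log units; beyond the scatter), so ring count alone does not order these three compounds. Nothing available here explains these shifts. Going by these compounds, whether one chlorine alone would hold this number remains open. So does the effect of a methoxy or trifluoromethyl group in place of the chlorines.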